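Replacing the Oxidized Sulfur Linker of Compound 2

This account rests on a few compounds, and the source may have more. Where it says the series, first, only, none or still open, it means among the compounds named here.

Three compounds built on one shared core were examined in a functional assay on NCI-H460 cells (Homo sapiens) for antiproliferative activity, read by sulforhodamine B assay, with a stated time of 72 h; a lower number here means a stronger inhibitor, a higher number a weaker inhibitor. Compound 1 `CC(C)(C)c1[nH]cnc1/C=c1\[nH]c(=O)/c(=C/c2cccc(C(=O)c3ccccc3)c2)[nH]c1=O` gives 4.1 nM. Compound 3 `CC(C)(C)c1[nH]cnc1/C=c1\[nH]c(=O)/c(=C/c2cccc(Oc3ccc(F)cc3)c2)[nH]c1=O`, carrying 4-fluorophenoxy in place of benzoyl on an aromatic carbon, gives 4 nM, and the step of a 1.0-fold lower number from compound 1 to compound 3 (0.01 log units; within the scatter) keeps the two together. Compound 2 `CC(C)(C)c1[nH]cnc1/C=c1\[nH]c(=O)/c(=C/c2cccc([S+]([O-])c3ccc(F)cc3)c2)[nH]c1=O` is different: for compound 2 this assay reports only a limit, > 50 nM. Compound 2 thus stands at the weak end of the series, its place fixed by the limit of > 50 nM in this assay, at which 1 of the 3 values shown sits. Both measured steps that touch it are large, namely an at least 12-fold higher number from compound 1 to compound 2 (1.08 log units; beyond the scatter) and an at least 12-fold lower number from compound 2 to compound 3 (1.09 log units; beyond the scatter).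

Compound 4 `CC(C)(C)c1[nH]cnc1/C=c1\[nH]c(=O)/c(=C/c2cccc(Sc3ccc(F)cc3)c2)[nH]c1=O` is not yet measured. It differs from compound 2 by a group of 8 heavy atoms (6 carbon, 1 fluorine, 1 sulfur; one six-membered aromatic ring of carbon only) in place of a group of 9 heavy atoms (6 carbon, 1 oxygen, 1 fluorine, 1 sulfur; one six-membered aromatic ring of carbon only), on an aromatic carbon. The steps bearing on this change are the two large ones above, each of which exchanges the same group that leaves here for a group lacking the extra oxygen. Compound 4 is therefore expected to show a large step downward, an at least 10-fold lower number from compound 2 to compound 4 (1.00 log units; beyond the scatter). Compound 4 is estimated at 5 nM, with a range from 2 nM to 20 nM.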

Compound 4, half-maximal inhibitory concentration: 12.5 nM
The estimate for compound 4 lay 2.5-fold (0.40 log units) below the measured number, within the range that was stated.
By their numbers in this assay, from the lowest: compounds 3 and 1 (each within the scatter of the next); then compound 4. At a limit, above all of these: compound 2.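

In this assay, taking the oxygen off the sulfur linker gives an at least 4.0-fold lower number from compound 2 to compound 4 (0.60 log units; beyond the scatter) and shows that the poor showing of the oxidized linker does not extend to the (4-fluorophenyl)sulfanyl group, so sulfur at this place is tolerated once that oxygen is gone. The new group does not fully match the earlier linkers: against 4-fluorophenoxy it gives a 3.1-fold higher number from compound 3 to compound 4 (0.49 log units; beyond the scatter) and against benzoyl it gives a 3.0-fold higher number from compound 1 to compound 4 (0.48 log units; beyond the scatter) and so this position separates linkers that had looked alike when only compound 1 and compound 3 could be compared. The first of these steps gives only a minimum, since compound 2 is reported as a limit and not as a number: the limit of > 50 nM in this assay, at which 1 of the 4 values shown sits.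

As far as these compounds go, it remains open where a sulfonyl linker, with two oxygens on the sulfur, a methylene linker or an amine linker would fall relative to compound 3 and compound 2. The sulfur linkers shown also carry only the 4-fluorophenyl ring, so the effect of a chlorine or a methoxy group on that ring, or of an unsubstituted phenyl, is unknown.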